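The source may hold more compounds than are shown below. What is called first, only, known or untested is meant among the compounds shown, and "the series" means these compounds.

Measured so far:

Compound 1 `CNC(=O)c1cc(C(=O)NC2CCOCC2)cn(Cc2ccccc2)c1=O` gives >= 174 ug/mL in a physicochemical assay for solubility (on this read-out higher numbers stand for higher solubility and lower numbers for lower solubility), which is a limit of the assay rather than a number.
Compound 2 `CNC(=O)c1cc(C(=O)NC2CC2)c(C)n(Cc2ccccc2)c1=O` gives >= 126 ug/mL in this assay, again only a limit.
Compound 3 `CNC(=O)c1cc(C(=O)NC2CC2)cn(Cc2cccc3[nH]c(C)nc23)c1=O` gives >= 198 ug/mL in this assay, also a limit.

Within the data shown here, every value here is a limit, so the three measured compounds cannot be ranked against one another, and no step between them can be sized. Compound 1 sits at the limit of >= 174 ug/mL in this assay, at which 1 of the 3 values shown sits; what is known of it is only that its solubility is not lower than that limit.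

Compound 4 `CNC(=O)c1cc(C(=O)NCCO)cn(Cc2ccccc2)c1=O` is not yet measured. It differs from compound 1 in one place: 2-hydroxyethyl in place of oxan-4-yl on an amide-type nitrogen. Among the measured compounds shown here, no measured step shows what this change does in this assay. With compound 1 already at a limit, the expectation for compound 4 is a solubility in the same high region, with no step beyond the usual scatter, that is a step that the limit leaves unreadable from compound 1 to compound 4 as the expected change. For compound 4 the estimate in this assay is 200 ug/mL, expected to fall between 90 ug/mL and 450 ug/mL, most likely reported again as a limit.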

Compound 4, solubility: >= 140 ug/mL
Compound 4 ended at the assay's limit (the forecaster's own chance of this, stated with the estimate: 75%); the middle value does not contradict the limit.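

In this assay compound 4 gives >= 140 ug/mL, a limit of the assay. Compound 1 gives >= 174 ug/mL, also a limit, so no step can be read from compound 1 to compound 4. The compounds shown leave open whether 2-hydroxyethyl in place of oxan-4-yl on an amide-type nitrogen changes solubility at all.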